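The source may hold more compounds than are shown below. What is called first, only, known or untested is meant among the compounds shown, and "the series" means these compounds.

Compound 1 `COC(=O)c1sc(-c2ccc(Cl)cc2)nc1C(Br)Br` — 222000 nM
Compound 2 `CN(C)C(=O)c1sc(-c2ccc(Cl)cc2)nc1C(Br)Br` — 163000 nM
Compound 3 `CCN(CC)C(=O)c1sc(-c2ccc(Cl)cc2)nc1C(Br)Br` — 63500 nM

In an ADME assay on BHK15 cells (Mesocricetus auratus) for inhibition, read by XTT assay, with a stated time of 36 h (a lower number here means a stronger inhibitor of growth, a higher number a weaker inhibitor of growth), compound 1 gives the highest of the three numbers. Its nearest neighbour is compound 2, reached by a 1.4-fold lower number from compound 1 to compound 2 (0.13 log units; within the scatter), a step within the scatter. The step to compound 3, a 3.5-fold lower number from compound 1 to compound 3 (0.54 log units; beyond the scatter), is modest but beyond the scatter, and a 2.6-fold lower number from compound 2 to compound 3 (0.41 log units; beyond the scatter) points the same way.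

Compound 4 `O=C(NC[C@@H](O)CO)c1sc(-c2ccc(Cl)cc2)nc1C(Br)Br` has not yet been measured in this assay. Its change from compound 1 is (2,3-dihydroxypropyl)amino in place of methoxy on a carbonyl carbon. Both measured steps from compound 1 replace the methoxy on the carbonyl carbon with an amine, so they bear directly on this step; one was within the scatter and the other modest. Neither carries the hydroxyl groups of the (2,3-dihydroxypropyl)amino group, so the data give no closer guide. Compound 4 is therefore expected to give a number somewhat below compound 1, a step of about a 1.5-fold lower number from compound 1 to compound 4 (0.17 log units; within the scatter), with the estimate 150000 nM and a range from 50000 nM to 400000 nM.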

Compound 4, concentration for 50% growth inhibition: 158000 nM
Compound 4: middle estimate off by 1.1-fold (0.02 log units), on the low side; measured number inside the range.
By their numbers in this assay, from the lowest: compound 3; then compounds 4, 2 and 1 (each within the scatter of the next).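

In this assay, a chain carrying hydroxyl groups on the carbonyl carbon stays within the scatter of the methoxy group, with a 1.4-fold lower number from compound 1 to compound 4 (0.15 log units; within the scatter) here, and of the dimethylamino group, with a 1.0-fold lower number from compound 2 to compound 4 (0.01 log units; within the scatter) here. Putting an amine in place of methoxy therefore does not by itself give the step seen with diethylamino, and a 2.5-fold higher number from compound 3 to compound 4 (0.40 log units; beyond the scatter) separates that group from the (2,3-dihydroxypropyl)amino group. No supporting measurement is available to explain these differences.

The compounds shown leave open whether the hydroxyl groups or the defined stereocentre count for anything, since they include neither a plain propylamino group nor the opposite stereoisomer. They also leave open whether a longer chain, such as dipropylamino, would extend the step seen with diethylamino.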